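The source may report more compounds than this note shows. Statements on the series, on what has been measured and on what is new or still open speak of the compounds shown alone.

Measured compounds:
Compound 1 `CN(c1cccc2c1CN(c1nc(Nc3ccc(C(F)(F)F)cc3)ncc1C(F)(F)F)C2)S(C)(=O)=O`. In a functional assay on HepG2 cells (Homo sapiens) for antiproliferative activity, read by spectrophotometry, with a stated time of 2 days (on this read-out higher numbers stand for weaker inhibition of growth and lower numbers for stronger inhibition of growth), compound 1 gives > 30000 nM, a limit of the assay.
Compound 2 `Cc1ccc(Nc2ncc(C(F)(F)F)c(N3Cc4cccc(N(C)S(C)(=O)=O)c4C3)n2)c(Cl)c1`. In this assay compound 2 gives > 30000 nM, again a limit.
Compound 3 `Cc1ccc(Nc2ncc(C(F)(F)F)c(N3Cc4cccc(N(C)S(C)(=O)=O)c4C3)n2)cc1C`. In this assay compound 3 gives > 30000 nM, again a limit.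

Compound 3 therefore stands only at a limit, as do the two other values shown; all three sit at the limit of > 30000 nM in this assay, at which 3 of the 3 values shown sit. Compound 4 `COc1cc(Nc2ncc(C(F)(F)F)c(N3Cc4cccc(N(C)S(C)(=O)=O)c4C3)n2)cc(C(F)(F)F)c1` differs from compound 3 by 3-methoxy-5-(trifluoromethyl)phenyl in place of 3,4-dimethylphenyl on a nitrogen on an aromatic ring. The measured steps at the same position, a step that the two limits leave unreadable from compound 1 to compound 2, a step that the two limits leave unreadable from compound 1 to compound 3 and a step that the two limits leave unreadable from compound 2 to compound 3, remain unreadable because every value sits at the limit of > 30000 nM in this assay, at which 3 of the 3 values shown sit; none of them yields a size in this assay. For compound 4 the step of a number no higher from compound 3 to compound 4 (the limit leaves the size open) is expected to be no readable step, the result most likely being another limit. Compound 4 is estimated at 30000 nM, within 8000 nM to 100000 nM.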

Compound 4, concentration for 50% growth inhibition: 22100 nM
Compound 4: the middle estimate sits 1.4-fold (0.13 log units) above what was measured; low and high end bracket the measured number.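

At the position on a nitrogen on an aromatic ring, 3-methoxy-5-(trifluoromethyl)phenyl gives the only number in this assay that is not a limit, while the other values stand at one: the limit of > 30000 nM in this assay, at which 3 of the 4 values shown sit.

The steps are an at least 1.3-fold lower number from compound 3 to compound 4 (0.13 log units; that floor lies within the scatter), an at least 1.3-fold lower number from compound 2 to compound 4 (0.13 log units; that floor lies within the scatter) and an at least 1.3-fold lower number from compound 1 to compound 4 (0.13 log units; that floor lies within the scatter); each is only a floor, so no change beyond the scatter is established.

The compounds shown leave open how large these steps really are. They also leave open whether the methoxy alone gives a measurable number, and what an amine or a carboxylic acid on this phenyl would do.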